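Nitro for methoxy on the sulfonamide aryl ring

The source may report more compounds than this note shows. Statements on the series, on what has been measured and on what is new or still open speak of the compounds shown alone.

Among the compounds with values here, compound 2 `CCOC(=O)c1oc2ccc(N(Cc3ccccc3)S(=O)(=O)c3ccc(OC)cc3)cc2c1C` is one of two compounds measured so far. In a functional assay on HCT-116 cells (Homo sapiens) for inhibition, read by MTT assay, with a stated time of 72 h (on this read-out lower numbers stand for stronger inhibition and higher numbers for weaker inhibition), compound 2 gives > 40000 nM, which is a limit of the assay rather than a number. Compound 1 `CCOC(=O)c1oc2ccc(N(Cc3ccccc3)S(=O)(=O)c3ccc(Br)cc3)cc2c1C` gives 8700 nM in this assay, and the step of an at least 4.5-fold higher number from compound 1 to compound 2 (0.66 log units; beyond the scatter) is the only measured one; it sits at the limit of > 40000 nM in this assay, at which 1 of the 2 values shown sits. Compound 3 `CCOC(=O)c1oc2ccc(N(Cc3ccccc3)S(=O)(=O)c3ccc([N+](=O)[O-])cc3)cc2c1C` differs from compound 2 by nitro in place of methoxy on an aromatic carbon. Within the data shown here, no measured step covers this change, so the direction remains open. Compound 3 is estimated at 20000 nM, between 6000 nM and 60000 nM, an expected step of an at least 2.0-fold lower number from compound 2 to compound 3 (0.30 log units; that floor lies within the scatter).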

Compound 3, half-maximal inhibitory concentration: > 40000 nM
Compound 3 gave a limit, no number (the forecaster's own chance of this, stated with the estimate: 45%); middle value at least 2.0-fold (0.30 log units) from the limit.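

In this assay, nitro in place of bromo on this aromatic carbon, para to a large group, gives an at least 4.5-fold higher number from compound 1 to compound 3 (0.66 log units; beyond the scatter), so a second group besides methoxy fails to keep the number seen with bromo. Both values for compound 2 and compound 3 are limits, and the step between them cannot be read. Methoxy and nitro thus end at the same limit, and so far only bromo gives a number here: the limit of > 40000 nM in this assay, at which 2 of the 3 values shown sit.

From the compounds shown here alone, whether a chloro group, an amine or a carboxylic acid at this place would give a number stays open. Going by these compounds, how far compound 2 and compound 3 lie beyond the limit also stays open.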